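The compounds below may be only part of what the source reports. "The series", "measured", "known", "first", "only" and "open" are said of these compounds alone.

Measured compounds in a functional assay on KB3 cells (Homo sapiens) for antiproliferative activity, read by MTT assay, with a stated time of 96 h; on this read-out higher numbers stand for weaker inhibition and lower numbers for stronger inhibition:
- compound 1, `C=C(C)[C@H]1CC=C(C)[C@@]2(O)[C@@H]1[C@H](c1ccccc1Br)O[C@@H]2C(=O)OC`, gives 5000 nM
- compound 2, `C=C(C)[C@H]1CC=C(C)C2=CO[C@@H](c3ccccc3F)[C@@H]21`, gives 1000 nM
- compound 3, `C=C(C)[C@H]1CC=C(C)[C@@]2(O)[C@@H]1[C@H](c1ccccn1)O[C@@H]2C(=O)OC`, gives 100000 nM

Among these three numbers compound 1 stands second highest: compound 2 gives the lower number, and compound 3 gives the higher one. Among the measured compounds shown here, the only single-point step among the measured compounds is a 20-fold higher number from compound 1 to compound 3 (1.30 log units; beyond the scatter), which concerns the aryl group on the shared core and not the ester.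

Compound 4, `C=C(C)[C@H]1CC=C(C)[C@@]2(O)[C@@H]1[C@H](c1ccccc1Br)O[C@@H]2C(=O)OCC`, differs from compound 1 only in the ester: methyl in place of hydrogen on a saturated chain carbon bound to an oxygen next to a carbonyl group. For the measured compounds named here, no measured step touches this part of the molecule, so nothing in the data indicates how the number moves when methoxycarbonyl becomes ethoxycarbonyl. Without such evidence, the expected step of no change at the digits printed from compound 1 to compound 4 (within the scatter) is small, most likely within the usual scatter, in no particular direction. Compound 4 is therefore estimated at 5000 nM, with a plausible range from 1500 nM to 16000 nM.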

Compound 4, half-maximal inhibitory concentration: 20000 nM
The estimate for compound 4 lay 4.0-fold (0.60 log units) below the measured number; the measured number lies above the stated range.
By their numbers in this assay, from the lowest: compound 2; then compound 1; then compound 4; then compound 3.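

The ester on the shared core is not a neutral position: in this assay, going from methoxycarbonyl to ethoxycarbonyl, which adds one methyl, gives a 4.0-fold higher number from compound 1 to compound 4 (0.60 log units; beyond the scatter). Among the compounds shown here, this is the first measured change at this part of the molecule, as the earlier single-point step concerned only the aryl group, and it shows that the number responds to even this small an addition. No measurement available here explains the direction or size of this move.

From the compounds shown here alone, a single added methyl cannot show a trend, so it remains open whether a longer chain such as a propyl ester, or the free carboxylic acid, would raise the number further or reverse the move. Going by these compounds, it is also open whether the same ester change would act alike with pyridin-2-yl in place of 2-bromophenyl.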